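A few compounds are considered here, and "the series" means these few. Any claim that something is new, unique, unknown or untested is made for them only; others in the source may bear on it.

Measured compounds in an assay for inhibition of NAD-dependent protein deacylase sirtuin-6 (Homo sapiens), read by HPLC, with stated times of 15 min and 1 h, tested at 333 uM; a higher number here means more inhibition at the concentration tested (going by the name of the read-out), a lower number less inhibition: compound 1 `O=C(O)CCNC(=O)CCCSC[C@H](NC(=O)OCc1ccccc1)C(=O)Nc1ccccc1` gives 43%; compound 2 `CCCCCCNC(=O)CCCSC[C@H](NC(=O)OCc1ccccc1)C(=O)Nc1ccccc1` gives "not active" (no number reported); compound 3 `CCNC(=O)CCCSC[C@H](NC(=O)OCc1ccccc1)C(=O)Nc1ccccc1` gives 15%.

Compound 2 stands without a single number in this assay, being recorded only as not active, whereas compound 3 is given a number. Compound 4 `CCCCCCCCNC(=O)CCCSC[C@H](NC(=O)OCc1ccccc1)C(=O)Nc1ccccc1` differs from compound 2 by ethyl in place of hydrogen on a saturated chain carbon, six bonds along the chain from an amide-type nitrogen. Going by the values given here, the only measured step, a number 28 percentage points lower from compound 1 to compound 3 (beyond the scatter), concerns a carboxy group at another place and gives little guidance here. Among the compounds with values here, compounds 3 and 2 show only that one gives a number and the other none. No shift beyond the scatter is therefore expected. Compound 4 is expected to give 5%, within a range from 0% to 20%.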

Compound 4, a percentage reported as inhibition, at one concentration (the size of the read-out at that concentration, not a potency): "not active" (no number reported)
For compound 4 the study gives words and no number; no gap can be computed for the estimate.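

In this assay, compound 2 and compound 4 are both recorded only in words, so no step can be read between them. No supporting evidence bears on this result. The compounds shown leave open whether ethyl in place of hydrogen at this place changes inhibition at all.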